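The compounds below may be only part of what the source reports. "The series", "measured", "known", "first", "only" and "open" are said of these compounds alone.

Of the compounds shown here, two so far carry a number in an ADME assay on HS27 cells (Homo sapiens) for antiproliferative activity, read by MTT assay, with a stated time of 24 h; a lower number here means a stronger inhibitor, a higher number a weaker inhibitor. Compound 1 `Nc1ncnc2c1ccn2-c1ccc(NC(=O)Nc2ccc(Cl)c(Cl)c2)cc1` gives 2900 nM. Compound 2 `O=C(Nc1ccc(-n2ccc3c(NC(=O)c4ccccc4)ncnc32)cc1)Nc1cccc(C(F)(F)F)c1` gives 4500 nM, the higher of the two numbers, though the gap to compound 1 lies within the scatter, so no order is claimed. Compound 3 `O=C(Nc1ccc(-n2ccc3c(NC(=O)c4ccccc4)ncnc32)cc1)Nc1ccc(Cl)c(Cl)c1` is not yet measured; it differs from compound 2 in one place: 3,4-dichlorophenyl in place of 3-(trifluoromethyl)phenyl on an amide-type nitrogen. Compound 1, at 2900 nM, likewise carries 3,4-dichlorophenyl on an amide-type nitrogen and sits close to compound 2. The step is therefore expected to be small, a 1.3-fold lower number from compound 2 to compound 3 (0.11 log units; within the scatter), nothing beyond the scatter in either direction. For compound 3 the expected value is 3500 nM, within 1500 nM to 8000 nM.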

Compound 3, half-maximal inhibitory concentration: 4500 nM
Compound 3: middle estimate off by 1.3-fold (0.11 log units), on the low side; low and high end bracket the measured number.
By their numbers in this assay, from the lowest: compounds 1, 2 and 3 (each within the scatter of the next).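

In this assay, 3,4-dichlorophenyl in place of 3-(trifluoromethyl)phenyl on the amide-type nitrogen gives no change at the digits printed from compound 2 to compound 3 (within the scatter) and so separates neither aryl group from the other at this position. Benzoyl in place of hydrogen on the nitrogen on an aromatic ring, with 3,4-dichlorophenyl held fixed, gives a 1.6-fold higher number from compound 1 to compound 3 (0.19 log units; within the scatter) and is likewise not resolved from the scatter. No evidence on the origin of either step is available.

On these data alone, whether an amine or a carboxylic acid on the aryl ring of the urea would shift the number beyond the scatter stays open. A longer acyl chain in place of benzoyl leaves the same question.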